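Chain length across four compounds: working notes

The source may hold more compounds than are shown below. What is called first, only, known or untested is meant among the compounds shown, and "the series" means these compounds.

Compound 1 `CCCCOCNc1n[n+]([O-])c2ccccc2[n+]1[O-]`, compound 2 `CCOCNc1n[n+]([O-])c2ccccc2[n+]1[O-]` and compound 3 `CCCCCCCOCNc1n[n+]([O-])c2ccccc2[n+]1[O-]` share one core and differ only in the length of the saturated chain. In a functional assay on A549 cells (Homo sapiens) for cytotoxicity, read by MTT assay, with a stated time of 72 h (on this read-out higher numbers stand for weaker inhibition and lower numbers for stronger inhibition), compound 1 gives 2320 nM, compound 2 gives 4090 nM and compound 3 gives 3490 nM. Compound 2 differs from compound 1 by hydrogen in place of ethyl on a saturated chain carbon, two bonds along the chain from an oxygen on a saturated carbon, a change that made a 1.8-fold higher number from compound 1 to compound 2 (0.25 log units; within the scatter). Compound 3 differs from compound 1 by propyl in place of hydrogen on a saturated chain carbon, four bonds along the chain from an oxygen on a saturated carbon. Compound 4 `CCCCCOCNc1n[n+]([O-])c2ccccc2[n+]1[O-]` has not yet been measured in this assay; it differs from compound 3 by hydrogen in place of ethyl on a saturated chain carbon, five bonds along the chain from an oxygen on a saturated carbon. This is the same kind of change as that between compound 1 and compound 2, though not the same: there the hydrogen enters two bonds along the chain from an oxygen on a saturated carbon, here five bonds along the chain from an oxygen on a saturated carbon. The coming step is expected to be small because the earlier one a 1.8-fold higher number from compound 1 to compound 2 (0.25 log units; within the scatter) stayed within the scatter, and because compound 1 at 2320 nM and compound 3 at 3490 nM also sit within the scatter of each other; the expected size is a 1.1-fold lower number from compound 3 to compound 4 (0.04 log units; within the scatter). Compound 4 is estimated at 3200 nM, between 1600 nM and 6500 nM.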

Compound 4, half-maximal inhibitory concentration: 2900 nM
Beside the measured number, compound 4's estimate is 1.1-fold (0.04 log units) above it, within the range that was stated.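

In this assay, the exchange of ethyl for hydrogen can be read on two cores, and the two steps do not differ beyond the scatter: the same change on two cores in this assay, a 1.8-fold higher number (0.25 log units; within the scatter) from compound 1 to compound 2 and a 1.2-fold lower number (0.08 log units; within the scatter) from compound 3 to compound 4, 2.1-fold (0.33 log units) apart, within the scatter of two such steps. The same holds for the exchange of hydrogen for propyl: the same change on two cores in this assay, a 1.5-fold higher number (0.18 log units; within the scatter) from compound 1 to compound 3 and a 1.4-fold lower number (0.15 log units; within the scatter) from compound 2 to compound 4, 2.1-fold (0.33 log units) apart, within the scatter of two such steps. With a 1.2-fold lower number from compound 3 to compound 4 (0.08 log units; within the scatter), a 1.4-fold lower number from compound 2 to compound 4 (0.15 log units; within the scatter) and a 1.3-fold higher number from compound 1 to compound 4 (0.10 log units; within the scatter), every step among the four compounds lies within the scatter, so the series shows no sign that these chain changes act differently from one core to another, but it does not show that any of them carries a real effect in a fixed direction or of a fixed size that could be transferred.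

Going by these compounds, what a longer chain, a branched chain, or a chain bearing an amine or a carboxylic acid would give in this assay remains open. On these data alone, whether the values stay this close together on other cell lines also remains open.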